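The source may report more compounds than this note shows. Statements on the series, on what has been measured and on what is new or still open speak of the compounds shown alone.

Measured so far in a physicochemical assay for solubility; on this read-out higher numbers stand for higher solubility and lower numbers for lower solubility:

Compound 1 `CNC(=O)c1cc(C(=O)N[C@H]2[C@@H]3C[C@@H](O)C[C@@H]32)cc2c1OC[C@H]2c1ccccc1`: >= 124 ug/mL
Compound 2 `CNC(=O)c1cc(C(=O)N[C@H]2CC[C@H](O)CC2)cc2c1OC[C@@]2(C)c1ccccc1`: >= 161 ug/mL
Compound 3 `CNC(=O)c1cc(C(=O)N[C@H]2C[C@@H]2C)cc2c1OC[C@@]2(C)c1ccccc1`: 3 ug/mL

Compound 1 stands at >= 124 ug/mL, which is a limit of this assay and not a number. Compound 2 also stands at a limit, >= 161 ug/mL. Only compound 3 has a plain number, 3 ug/mL.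

The next compound, compound 4 `CNC(=O)c1cc(C(=O)NC2CC2)cc2c1OC[C@H]2c1ccccc1`, keeps the core of compound 1 and changes one group: a group of 3 heavy atoms (3 carbon; one three-membered non-aromatic ring of carbon only) in place of a group of 7 heavy atoms (6 carbon, 1 oxygen; one three-membered non-aromatic ring of carbon only, one five-membered non-aromatic ring of carbon only), on an amide-type nitrogen. Cyclopropyl is the group that enters, on an amide-type nitrogen.

The closest measured comparison comes from another pair with a slightly different core. Its change is 2-methylcyclopropyl in place of 4-hydroxycyclohexyl on an amide-type nitrogen, and it gave an at least 53-fold lower number from compound 2 to compound 3 (1.72 log units; beyond the scatter). Among the compounds with values here, that large drop, beyond the scatter, is the only measured step that bears on this change, and it starts from a limit. It is a guide and not a rule, since a single pair cannot establish a pattern. On the strength of that step from compound 2 to compound 3, a similarly large fall is expected here. The expected change is an at least 12-fold lower number from compound 1 to compound 4 (1.09 log units; beyond the scatter), well beyond the scatter. For compound 4 the estimated value is 10 ug/mL, with an expected range from 3 ug/mL to 40 ug/mL.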

Compound 4, solubility: >= 190 ug/mL
Compound 4 ended at the assay's limit (the forecaster's own chance of this, stated with the estimate: 10%); middle value at least 19-fold (1.27 log units) away from the limit.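

In this assay compound 4 gives >= 190 ug/mL, which is a limit of the assay and not a number. Compound 1 also stands at a limit, so the step between compound 1 and compound 4 cannot be read. The compounds shown leave open how high the true values of these two lie, and whether they differ at all.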